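The source may report more compounds than this note shows. Statements on the series, on what has been measured and on what is new or still open speak of the compounds shown alone.

Measured so far:
compound 1 `CC1=CCC[C@H]2[C@](C)(CC3=CC(=O)C=C(N[C@@H](C(=O)O)C(C)C)C3=O)[C@@H](C)CC[C@]12C` — 7780 nM
compound 2 `CSCC[C@H](NC1=CC(=O)C=C(C(C)(C)C)C1=O)C(=O)O` — 88500 nM

In a functional assay on K562 cells (Homo sapiens) for cytotoxicity, read by MTT assay, with a stated time of 72 h (a higher number here means a weaker inhibitor, a lower number a stronger inhibitor), compound 1 gives 7780 nM, the lower of the two numbers. For the measured compounds named here, compound 2, which carries a different substituent on the amine nitrogen and a different group on the ring, gives 88500 nM; the gap between these two values lies beyond the scatter, but the compounds differ in more than one place, so the pair shows no single step.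

Compound 3 `CC1=CCC[C@H]2[C@](C)(CC3=CC(=O)C=C(N[C@@H](C)C(=O)O)C3=O)[C@@H](C)CC[C@]12C` is not yet measured in this assay. It differs from compound 1 by a single change, (1-carboxyethyl in place of 1-carboxy-2-methylpropyl on an amine nitrogen). Going by the values given here, no measured pair isolates a change of this kind, so there is nothing to scale the step by. The change is small in size, and the expected step is modest, likely within the scatter, if anything toward a somewhat higher number. The step from compound 1 to compound 3 is expected to be a 1.3-fold higher number from compound 1 to compound 3 (0.11 log units; within the scatter). For compound 3 the expected value in this assay is 10000 nM, with a range from 4000 nM to 25000 nM.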

Compound 3, half-maximal inhibitory concentration: 15800 nM
Compound 3: middle estimate off by 1.6-fold (0.20 log units), on the low side, and the stated range covers the measured number.
By their numbers in this assay, from the lowest: compound 1; then compound 3; then compound 2.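

In this assay, for the compounds shown here, 1-carboxyethyl in place of 1-carboxy-2-methylpropyl on the amine nitrogen gives a 2.0-fold higher number from compound 1 to compound 3 (0.31 log units; beyond the scatter), the first step that can be read at a single place. With the rest of compound 1 unchanged, the substituent on this nitrogen does register in the read-out, and the group with fewer carbon atoms sits on the higher-number side, although the step is modest. Nothing available explains this step.

A single step cannot show whether the number tracks the carbon count of this substituent or something particular to each group, and a longer chain or a benzyl group on the same carbon would help separate those readings. All three compounds shown carry the carboxylic acid, so what a primary amide or an ester in its place would do remains open.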